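Pyridin-2-yl Piperazine Analogue in a Triazole Thioether Series

The source may report more compounds than this note shows. Statements on the series, on what has been measured and on what is new or still open speak of the compounds shown alone.

Compound 1, `CC(C)(C)c1ccc(-c2nnc(SCCCN3CCN(c4ccccc4)CC3)[nH]2)cc1`: in a functional assay on MCF7 cells (Homo sapiens) for cytotoxicity, read by MTT assay, with a stated time of 24 h (a higher number here means a weaker inhibitor, a lower number a stronger inhibitor), compound 1 gives only the limit > 300000 nM.
Compound 2, `Cc1ccc(-c2nnc(SCCCN3CCN(c4cccc(Cl)c4)CC3)[nH]2)cc1`: in this assay compound 2 gives only the limit > 300000 nM.
Compound 3, `Cc1cccc(-c2nnc(SCCCN3CCN(c4ccccc4)CC3)[nH]2)c1`: in this assay compound 3 gives only the limit > 300000 nM.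

Compound 3 therefore stands at the limit of > 300000 nM in this assay, at which 3 of the 3 values shown sit, and nothing separates it from its two neighbours. Within the data shown here, the single step between measured compounds, a step that the two limits leave unreadable from compound 1 to compound 3, cannot be read from two limits. Compound 4, `Cc1cccc(-c2nnc(SCCCN3CCN(c4ccccn4)CC3)[nH]2)c1`, carries pyridin-2-yl in place of phenyl on an amine nitrogen in a ring. Among the measured compounds shown here, no measured step touches this position, so no direction can be drawn; the expectation rests only on the three limits. Compound 4 is therefore expected to stay at the limit, with an estimate of 300000 nM between 100000 nM and 1000000 nM, which means an expected step of a number no higher from compound 3 to compound 4 (the limit leaves the size open).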

Compound 4, half-maximal inhibitory concentration: > 300000 nM
Compound 4: no number, only a limit (the forecaster's own chance of this, stated with the estimate: 85%); the middle value sits exactly at the limit.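

Compound 3 and compound 4 each give only a limit, so no step between them can be read: the limit of > 300000 nM in this assay, at which 4 of the 4 values shown sit.

The compounds shown leave open whether any change to the shared core yields a readable value in this assay.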